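A few compounds are considered here, and "the series" means these few. Any claim that something is new, unique, unknown or untested is made for them only; others in the source may bear on it.

In a functional assay on the whole organism (strain Sprague-Dawley) for inhibition, with Rattus norvegicus as the target, with a stated time of 10 min (on this read-out lower numbers stand for an effect already at smaller amounts and higher numbers for an effect only at larger amounts of compound), compound 1 `C=CCOc1ccccc1-c1ncc(C(=O)O)c(=O)[nH]1` gives 0.5 mg/kg. Compound 3 `C=CCOc1ccccc1-c1ncc(C(=O)OCC)c(=O)[nH]1` carries ethyl in place of hydrogen on an oxygen next to a carbonyl group, and the step of no change at the digits printed from compound 1 to compound 3 (within the scatter). In this assay compound 3 gives 0.5 mg/kg. Compound 2 `O=C(O)c1cnc(-c2cccc(C(F)(F)F)c2)[nH]c1=O` is built on a different core; how the core of compound 2 differs from the core of compound 1 is not broken down here. In this assay compound 2 gives 33 mg/kg, a number far higher than those of compound 1 and compound 3. Compound 4 `CCOC(=O)c1cnc(-c2cccc(C(F)(F)F)c2)[nH]c1=O` has not yet been measured; it carries the same change relative to compound 2, (ethyl in place of hydrogen on an oxygen next to a carbonyl group), at the same place. Compound 4 is expected to give 33 mg/kg, with a likely range from 12 mg/kg to 90 mg/kg. This expectation rests on the earlier step because the step of no change at the digits printed from compound 1 to compound 3 (within the scatter) left the number where it stood, so the estimated step is no change at the digits printed from compound 2 to compound 4 (within the scatter).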

Compound 4, dose for 50% inhibition: 50 mg/kg
The estimate for compound 4 lay 1.5-fold (0.18 log units) below the measured number; low and high end bracket the measured number.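

In this assay, putting ethyl in place of the hydrogen on the carboxy group of compound 2 gives a 1.5-fold higher number from compound 2 to compound 4 (0.18 log units; within the scatter). Set beside the earlier step, the change from carboxy to ethoxycarbonyl behaves alike on the two cores: the same change on two cores in this assay, no change at the digits printed (within the scatter) from compound 1 to compound 3 and a 1.5-fold higher number (0.18 log units; within the scatter) from compound 2 to compound 4, 1.5-fold (0.18 log units) apart, within the scatter of two such steps. This shows that the change carried over between these two cores in this assay, but it does not explain why, and two cores cannot show that it would hold on a third. The compounds shown leave open whether a longer chain on the same oxygen, or an amine in place of that oxygen, would also leave the number within the scatter.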